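This account rests on a few compounds, and the source may have more. Where it says the series, first, only, none or still open, it means among the compounds named here.

Measured compounds in a functional assay on HepG2 cells (Homo sapiens) for cytotoxicity, read by MTT assay, with a stated time of 48 h; a higher number here means a weaker inhibitor, a lower number a stronger inhibitor:
Compound 1 `CCc1nnc(SCC(=O)c2ccccc2)n1N1C(=O)c2ccccc2C1=O` gives > 200000 nM, a limit of the assay.
Compound 2 `COc1cc(-c2nnc(SCC(=O)c3ccc(Cl)cc3)n2N2C(=O)c3ccccc3C2=O)cc(OC)c1OC` gives 22000 nM.
Compound 3 `COc1cc(-c2nnc(SC)n2N2C(=O)c3ccccc3C2=O)cc(OC)c1OC` gives > 200000 nM, also a limit of the assay.

Compound 3 stands at the upper limit of this assay, so only a bound and no number is known for it; the limit of > 200000 nM in this assay, at which 2 of the 3 values shown sit, shows how common that outcome is among these compounds. Compound 4 `COc1cc(-c2nnc(SCC(=O)c3ccccc3)n2N2C(=O)c3ccccc3C2=O)cc(OC)c1OC` differs from compound 3 by benzoyl in place of hydrogen on a saturated chain carbon bound to a sulfur. Among the compounds with values here, the one measured step that bears on this change runs the other way: the step of an at least 9.0-fold higher number from compound 2 to compound 3 (0.95 log units; beyond the scatter), in which an aryl carbonyl group on the same carbon was removed and the number rose out of the measurable range. Compound 4 restores that group, without the chlorine of compound 2, so the reverse direction is expected, a lower number in this assay, though compound 1, which also carries the benzoylmethyl chain on a different core, sits at the limit and tempers the expectation. Compound 4 is therefore estimated at 45000 nM, ranging from 15000 nM to 200000 nM, a step of an at least 4.4-fold lower number from compound 3 to compound 4 (0.64 log units; beyond the scatter) being expected.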

Compound 4, half-maximal inhibitory concentration: 171000 nM
The estimate for compound 4 lay 3.8-fold (0.58 log units) below the measured number; the range from low to high includes it.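

In this assay, the chloro on an aromatic carbon now carries weight: a 7.8-fold higher number from compound 2 to compound 4 (0.89 log units; beyond the scatter), with hydrogen in place of chloro, so the benzoyl-bearing compound 4 stays well short of compound 2. Benzoyl in place of hydrogen on the saturated chain carbon bound to a sulfur is not shown to do anything by itself, with an at least 1.1-fold lower number from compound 3 to compound 4 (0.06 log units; that floor lies within the scatter), and 3,4,5-trimethoxyphenyl in place of ethyl likewise gives only an at least 1.1-fold lower number from compound 1 to compound 4 (0.06 log units; that floor lies within the scatter). Neither floor shows a real change, and both rest on limits of the assay: the limit of > 200000 nM in this assay, at which 2 of the 4 values shown sit.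

On these data alone, the true numbers of compound 1 and compound 3 remain unknown, so the size of these two steps stays open. As far as these compounds go, it is also open whether bromo, fluoro or methoxy in place of chloro on that aromatic carbon would match compound 2, and what an amine on the chain would do.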